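Swapping a sulfonamide for an oxazole on a fused core

The source may hold more compounds than are shown below. What is called first, only, known or untested is meant among the compounds shown, and "the series" means these compounds.

Of the compounds shown here, two have been tested in a functional assay on CHO cells for agonist activity at Alpha-1A adrenergic receptor (Homo sapiens), read by FLIPR and calcium flux; a lower number here means a smaller maximal response, a higher number a larger maximal response. Compound 1, with the structure `Cc1c(OCC2=NCCN2)ccc(Cl)c1NS(C)(=O)=O`, reaches 60%. Compound 2, with the structure `CCS(=O)(=O)Nc1cccc2c1CCC2c1ncc[nH]1`, reaches 86% in this assay. Among the two numbers measured, compound 2 stands highest, and its nearest neighbour is compound 1, whose response lies lower by a gap beyond the usual scatter of this kind of measurement.

Compound 3, with the structure `c1cc(-c2ncco2)c2c(c1)C(c1ncc[nH]1)CC2`, has not yet been measured in this assay. It differs from compound 2 in one place: 1,3-oxazol-2-yl in place of (ethylsulfonyl)amino on an aromatic carbon. For the measured compounds named here, compound 1 and compound 2 differ in many places at once, so no single step between measured compounds can guide the expectation here, and the prediction rests on the one change alone.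

Compound 3 is expected to give a somewhat smaller maximal response than compound 2, a step of a number 14 percentage points lower from compound 2 to compound 3 (beyond the scatter), which may or may not exceed the scatter. The estimate for compound 3 in this assay is 72%, with a likely range from 45% to 95%.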

Compound 3, largest response reached (Emax), in percent of the reference or control that the assay uses: 63%
Estimate against measurement, compound 3: 9 percentage points above; the measured number falls inside the stated range.
By their numbers in this assay, from the lowest: compounds 1 and 3 (each within the scatter of the next); then compound 2.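

Placing 1,3-oxazol-2-yl in place of (ethylsulfonyl)amino on this aromatic carbon gives the only single-place comparison available in this assay and the step is a number 23 percentage points lower from compound 2 to compound 3 (beyond the scatter). This shows that the group at this position affects the maximal response, something compounds 1 and 2 could not show because they differ in many places at once, yet the (ethylsulfonyl)amino group is not essential for a response, as compound 3 still gives 63%. The swap changes several things together, including the chain, the new aromatic ring and the hydrogen-bond donor count, and no measurement here bears on which of these accounts for the lower response.

On these data alone, it remains open whether an amine, a carboxylic acid or a longer chain such as (propylsulfonyl)amino on the same aromatic carbon would give a response closer to that of compound 2 or further from it. A single pair also cannot tell whether the same replacement would produce a step of similar size on a different core.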